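This account rests on a few compounds, and the source may have more. Where it says the series, first, only, none or still open, it means among the compounds named here.

For the measured compounds named here, in a functional assay on PANC-1 cells (Homo sapiens) for inhibition, read by MTT assay, with a stated time of 24 h (a lower number here means a stronger inhibitor, a higher number a weaker inhibitor), compound 2 `CC1(C)[C@H]2CC[C@]1(C)N(Cc1cn(-c3ccccc3O)nn1)C(=O)C2` gives 230 nM, the higher of the two numbers so far, while compound 1 `CC1(C)[C@H]2CC[C@]1(C)N(Cc1cn(-c3ccc(F)cc3)nn1)C(=O)C2` gives 110 nM. Compound 3 `CC1(C)[C@H]2CC[C@]1(C)N(Cc1cn(-c3cccc(Br)c3)nn1)C(=O)C2` has 3-bromophenyl in place of 2-hydroxyphenyl on an aromatic nitrogen. Going by the values given here, the only measured step that changes the group there is a 2.1-fold higher number from compound 1 to compound 2 (0.32 log units; beyond the scatter), which is modest. Like compound 1, compound 3 carries a halogen on its phenyl, so a similarly modest move back towards a lower number is expected, an estimated 1.5-fold lower number from compound 2 to compound 3 (0.19 log units; within the scatter). For compound 3 the expected value is 150 nM, within an estimated range of 60 nM to 380 nM.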

Compound 3, half-maximal inhibitory concentration: 90 nM
Compound 3: the middle estimate sits 1.7-fold (0.22 log units) above what was measured; low and high end bracket the measured number.
By their numbers in this assay, from the lowest: compounds 3 and 1 (each within the scatter of the next); then compound 2.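

In this assay, the 3-bromophenyl group on the aromatic nitrogen gives a 2.6-fold lower number from compound 2 to compound 3 (0.41 log units; beyond the scatter) and so joins 4-fluorophenyl in standing below 2-hydroxyphenyl, which shows that this gap does not depend on one particular halogen-bearing phenyl. Between those two groups there is a 1.2-fold lower number from compound 1 to compound 3 (0.09 log units; within the scatter) and so they cannot be told apart here, even though the halogen and its place on the phenyl both differ. No supporting evidence is available to explain these differences. From the compounds shown here alone, it remains open whether an amine, a carboxylic acid or a methoxy group on the phenyl would read like compound 2 or like compound 3.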